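From Pyrrolidinyl to Cyclopropyl: Forecasting a Lipophilicity Shift

The source may report more compounds than this note shows. Statements on the series, on what has been measured and on what is new or still open speak of the compounds shown alone.

Of the compounds shown here, three sharing one core have been measured in a physicochemical assay for lipophilicity; on this read-out higher numbers stand for higher lipophilicity and lower numbers for lower lipophilicity. Compound 1 `Cc1cc(-c2noc([C@H](C)NC(=O)c3cc(C(F)(F)F)nn3C)n2)ccn1` gives 3.3, compound 2 `C[C@H](NC(=O)c1cc(C(F)(F)F)nn1C)c1nc(-c2ccnc(N3CCCC3)c2)no1` gives 4.2, and compound 3 `C[C@H](NC(=O)c1cc(C(F)(F)F)nn1C)c1nc(-c2ccnc(N(C)C)c2)no1` gives 3.9. Compound 2 stands highest of the three: a number 0.30 log units lower from compound 2 to compound 3 (within the scatter) is within the scatter, while a number 0.90 log units higher from compound 1 to compound 2 (beyond the scatter) is beyond it. Compound 4 `C[C@H](NC(=O)c1cc(C(F)(F)F)nn1C)c1nc(-c2ccnc(C3CC3)c2)no1` differs from compound 2 in one place: cyclopropyl in place of pyrrolidin-1-yl on an aromatic carbon. Going by the values given here, the steps that bear on this are a number 0.90 log units higher from compound 1 to compound 2 (beyond the scatter) and a number 0.60 log units higher from compound 1 to compound 3 (beyond the scatter), where groups with one hydrogen-bond acceptor replaced methyl; cyclopropyl has none. Among the compounds with values here, no cyclopropyl compound has been measured, so a partial move back toward compound 1 is expected. Compound 4 is estimated at 3.9, with a range from 3.4 to 4.4. This means an expected a number 0.30 log units lower from compound 2 to compound 4 (within the scatter).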

Compound 4, distribution coefficient: 4.1
Beside the measured number, compound 4's estimate is 0.20 log units below it; low and high end bracket the measured number.
By their numbers in this assay, from the lowest: compound 1; then compounds 3, 4 and 2 (each within the scatter of the next).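

In this assay, cyclopropyl next to the ring nitrogen also stands clear of methyl (a number 0.80 log units higher from compound 1 to compound 4 (beyond the scatter)), so the step from methyl at this place does not need a group with a hydrogen-bond acceptor. Set against the two nitrogen-linked groups (a number 0.10 log units lower from compound 2 to compound 4 (within the scatter); a number 0.20 log units higher from compound 3 to compound 4 (within the scatter)), cyclopropyl cannot be told apart from pyrrolidin-1-yl or dimethylamino. No measurement at hand explains this likeness. Still open, going by these compounds, is whether methoxy or a longer chain such as n-propyl would stay level with these three groups or fall back toward compound 1.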